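Dropping the methoxy group from compound 2

The compounds below may be only part of what the source reports. "The series", "measured", "known", "first", "only" and "open" are said of these compounds alone.

Measured in a functional assay (aorta) with Oryctolagus cuniculus as the target; a higher number here means weaker binding, a lower number tighter binding:
compound 1 `COC(=O)c1ccc(OCCCN2CCC(C(c3ccc(F)cc3)c3ccc(F)cc3)CC2)c(OC)c1` (1.26 nM)
compound 2 `COc1cc(OCCCN2CCC(C(c3ccc(F)cc3)c3ccc(F)cc3)CC2)ccc1C(C)=O` (3.16 nM)

Of these two compounds, compound 2 carries the higher number, 3.16 nM in this assay, and so binds less tightly. Going by the values given here, the only measured step is a 2.5-fold higher number from compound 1 to compound 2 (0.40 log units; beyond the scatter) and it lies beyond the scatter. That step replaces a whole aryl group, with 4-acetyl-3-methoxyphenyl in place of 2-methoxy-4-(methoxycarbonyl)phenyl.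

Compound 3 `CC(=O)c1ccc(OCCCN2CCC(C(c3ccc(F)cc3)c3ccc(F)cc3)CC2)cc1` has not yet been measured. It differs from compound 2 by one change, hydrogen in place of methoxy on an aromatic carbon (4-acetyl-3-methoxyphenyl becomes 4-acetylphenyl).

Among the compounds with values here, no measured step isolates the loss of a methoxy group, so the step to compound 1 offers only a rough guide to size, and it says nothing firm about direction. A shift no larger than that modest step seems the fair expectation, and the step expected is a 1.3-fold higher number from compound 2 to compound 3 (0.10 log units; within the scatter) as an estimate. The estimated value for compound 3 is 4 nM (expected range 1.3 nM to 12 nM).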

Compound 3, dissociation constant: 2.51 nM
Compound 3: the middle estimate sits 1.6-fold (0.20 log units) above what was measured; the range from low to high includes it.
By their numbers in this assay, from the lowest: compounds 1, 3 and 2 (each within the scatter of the next, the first and the last beyond it).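

In this assay, the methoxy group ortho to an acetyl group can be replaced by hydrogen without a shift that exceeds the scatter (a 1.3-fold lower number from compound 2 to compound 3 (0.10 log units; within the scatter)), so on these numbers this group is dispensable at this position on the six-membered aromatic ring, at least with the acetyl group in place. The wider replacement gives the same reading (a 2.0-fold higher number from compound 1 to compound 3 (0.30 log units; within the scatter)): although compound 1 and compound 2 stood apart beyond the scatter, 4-acetylphenyl cannot be separated from 2-methoxy-4-(methoxycarbonyl)phenyl in this assay. No measured property is available to account for any of these numbers.

The compounds shown leave open whether this tolerance extends beyond hydrogen and methoxy at this position, for instance to a chlorine atom, an ethoxy group or an amine, and whether it would hold if a carboxylic acid or an amide took the place of the acetyl group. They also do not show how the numbers would respond to a longer chain linking the aryl ether to the shared core, or to removing a fluorine atom from the core.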